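Series notes: methoxy for hydrogen from compound 2 to compound 3

A few compounds are considered here, and "the series" means these few. Any claim that something is new, unique, unknown or untested is made for them only; others in the source may bear on it.

Measured so far:
compound 1, `Cc1ccccc1-c1nc(C)c(COc2ccc3c(c2)OCC3CC(=O)O)s1`, 10.7%
compound 2, `COc1cc(OC)cc(-c2nc(C)c(COc3ccc4c(c3)OCC4CC(=O)O)s2)c1`, 17.5%

Both compounds share one core and differ only in the aryl group on the aromatic carbon. In a functional assay on CHO cells for agonist activity at Free fatty acid receptor 1 (Homo sapiens), read by FLIPR and calcium flux, tested at 100 nM (a lower number here means a weaker effect, a higher number a stronger effect of the compound at the concentration tested), compound 1 gives 10.7%, and in this assay compound 2 gives 17.5%. The step is a number 6.8 percentage points higher from compound 1 to compound 2 (within the scatter), so the two numbers lie within the scatter of each other and neither compound can be called the stronger on these data.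

Compound 3, `COc1cc(-c2nc(C)c(COc3ccc4c(c3)OCC4CC(=O)O)s2)cc(OC)c1OC`, differs from compound 2 by methoxy in place of hydrogen on an aromatic carbon.

For the measured compounds named here, only one measured step exists, that from compound 1 to compound 2, and it concerns an exchange of the whole aryl group, not the entry of a further methoxy; it came out as a number 6.8 percentage points higher from compound 1 to compound 2 (within the scatter). Going by the values given here, no measured step adds a methoxy to an already substituted aryl group, so nothing points to a change in either direction. The step is therefore expected to be a number 0.5 percentage points higher from compound 2 to compound 3 (within the scatter), not beyond the scatter.

For compound 3 the estimate in this assay is 18%, with a range from 5% to 35%.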

Compound 3, a percentage reported as activity, at one concentration (the size of the read-out at that concentration, not a potency): 7.47%
The estimate for compound 3 lay 10.5 percentage points above the measured number, within the range that was stated.
By their numbers in this assay, from the lowest: compounds 3, 1 and 2 (each within the scatter of the next).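

For the compounds shown here, this is the first measured step at a single position on the aryl group: methoxy in place of hydrogen, on an aromatic carbon ortho to two methoxy groups and para to a large group. In this assay the step is a number 10 percentage points lower from compound 2 to compound 3 (within the scatter), so at the concentration tested, this position accepts methoxy without an effect that can be told apart from the scatter, and compound 2 and compound 3 cannot be ranked on these data. No measurement that would account for this result is available.

As far as these compounds go, it remains open whether another group at this carbon, such as hydroxy, an amine or a carboxylic acid, would give a step beyond the scatter. Also open, from the compounds shown here alone, is whether methoxy at this carbon gives a similar step when the two methoxy groups ortho to it are absent.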